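The source may hold more compounds than are shown below. What is called first, only, known or untested is meant among the compounds shown, and "the series" means these compounds.

Compound 1, `CCSc1nc(N)c2nc(O)n(Cc3ccccc3)c2n1`, in a functional assay on the whole organism for activation, with Mus musculus as the target (on this read-out higher numbers stand for an effect only at larger amounts of compound and lower numbers for an effect already at smaller amounts), gives 0.1 mg/kg.
Compound 2, `Nc1nc(SCc2ccccc2)nc2c1nc(O)n2Cc1ccccc1`, in this assay reaches only > 1 mg/kg, which is a limit of the assay and not a number.
Compound 3, `CCCCCNc1nc(N)c2nc(O)n(Cc3ccccc3)c2n1`, in this assay gives 0.3 mg/kg.

Compound 3 thus holds the higher of the two numbers in this assay; its nearest neighbour is compound 1, the gap being a 3.0-fold higher number from compound 1 to compound 3 (0.48 log units; beyond the scatter), and the remaining value is a limit. Compound 4, `CCCCSc1nc(N)c2nc(O)n(Cc3ccccc3)c2n1`, has not yet been measured and differs from compound 3 in one place: butylsulfanyl in place of pentylamino on an aromatic carbon. Going by the values given here, two measured steps bear on this change. Replacing the sulfur-bound group by the amine cost potency, as a 3.0-fold higher number from compound 1 to compound 3 (0.48 log units; beyond the scatter) shows, so returning to a sulfanyl group might lower the number again. On the other hand, a bulkier group on the sulfur gave an at least 10-fold higher number from compound 1 to compound 2 (1.00 log units; beyond the scatter), and butylsulfanyl is longer than ethylsulfanyl. Balancing these, a small lowering or no step beyond the scatter is expected. Compound 4 is therefore estimated at 0.2 mg/kg in this assay, with an expected range from 0.05 mg/kg to 1 mg/kg. This estimate corresponds to an expected step of a 1.5-fold lower number from compound 3 to compound 4 (0.18 log units; within the scatter).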

Compound 4, minimum effective dose: 0.3 mg/kg
Beside the measured number, compound 4's estimate is 1.5-fold (0.18 log units) below it, within the range that was stated.
By their numbers in this assay, from the lowest: compound 1; then compounds 3 and 4 (each within the scatter of the next). At a limit, above all of these: compound 2.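

Swapping pentylamino for butylsulfanyl on the aromatic carbon between two ring nitrogen atoms leaves this assay unmoved, with no change at the digits printed from compound 3 to compound 4 (within the scatter), so a sulfur link at this position does not by itself give the lower number of the ethylsulfanyl compound. Chain length on the sulfur matters instead: lengthening ethylsulfanyl to butylsulfanyl gives a 3.0-fold higher number from compound 1 to compound 4 (0.48 log units; beyond the scatter), while propyl in place of phenyl on the chain carbon bound to the sulfur gives an at least 3.3-fold lower number from compound 2 to compound 4 (0.52 log units; beyond the scatter). Compound 2 stands at a limit and not a number: the limit of > 1 mg/kg in this assay, at which 1 of the 4 values shown sits.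

Going by these compounds, whether methylsulfanyl or a longer chain such as hexylsulfanyl would shift the number further remains open. So does whether ethylamino would match ethylsulfanyl, which would separate the effect of the linking atom from that of chain length.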